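Replacing a biaryl with a phenoxy group on an isatin core

The compounds below may be only part of what the source reports. "The series", "measured", "known", "first", "only" and "open" are said of these compounds alone.

Measured compounds: compound 1 `O=C1C(=O)N(Cc2ccc(-c3ccc(Cl)nc3)cc2)c2ccc(OC(F)(F)F)cc21` with 4800 nM, compound 2 `Cn1cc(-c2ccc(CN3C(=O)C(=O)c4cc(OC(F)(F)F)ccc43)cc2)cn1` with 3300 nM, compound 3 `COc1ccccc1-c1ccc(CN2C(=O)C(=O)c3cc(OC(F)(F)F)ccc32)cc1` with 3900 nM, all in a functional assay on CHO cells for agonist activity at muscarinic acetylcholine receptor M5 (Homo sapiens), read by calcium flux; a higher number here means that more compound is needed for the effect, a lower number that less compound is needed.

Compound 3 sits in a narrow band with its two companions: the steps of a 1.2-fold lower number from compound 1 to compound 3 (0.09 log units; within the scatter) and a 1.2-fold higher number from compound 2 to compound 3 (0.07 log units; within the scatter) both lie within the scatter, so no ordering among the three can be claimed. Compound 4 `O=C1C(=O)N(Cc2ccc(Oc3ccccc3)cc2)c2ccc(OC(F)(F)F)cc21` carries the change (phenoxy in place of 2-methoxyphenyl on an aromatic carbon). Both steps that bear on this aromatic carbon changed the attached group without a step beyond the scatter, so compound 4 is expected to show no step beyond the scatter either, with a 1.1-fold higher number from compound 3 to compound 4 (0.03 log units; within the scatter) as the expected shift. The estimate for compound 4 in this assay is 4200 nM, with a range from 1500 nM to 12000 nM.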

Compound 4, half-maximal effective concentration: 1900 nM
Compound 4: middle estimate off by 2.2-fold (0.34 log units), on the high side; measured number inside the range.
By their numbers in this assay, from the lowest: compounds 4, 2, 3 and 1 (each within the scatter of the next, the first and the last beyond it).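

Among the compounds shown here, with phenoxy in place of the earlier groups on this aromatic carbon, para to a large group, this assay shows steps beyond the scatter, which none of the earlier compounds showed among themselves: a 2.1-fold lower number from compound 3 to compound 4 (0.31 log units; beyond the scatter) and a 2.5-fold lower number from compound 1 to compound 4 (0.40 log units; beyond the scatter) are both modest. The position is therefore not wholly indifferent to the attached group, yet a 1.7-fold lower number from compound 2 to compound 4 (0.24 log units; within the scatter) shows that phenoxy is not separated from every earlier group.

From the compounds shown here alone, whether an amine or a longer chain in place of phenoxy would move the number further remains open. Nothing measured here accounts for the shift.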